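The source may hold more compounds than are shown below. What is called first, only, known or untested is meant among the compounds shown, and "the series" means these compounds.

Compound 3 `CN1CCn2nc(CNC(=O)[C@@H](N)CCSC[C@H]3O[C@@H](n4cnc5c(N)ncnc54)[C@H](O)[C@@H]3O)cc2C1` is one of three compounds that share a core and differ only in the side group carried on a saturated chain carbon bound to an amide-type nitrogen. In an assay on Sf9 cells for inhibition of histone-lysine N-methyltransferase EZH2 (Homo sapiens), read by scintillation counting, in the presence of a further agent that is not named here (on this read-out higher numbers stand for weaker inhibition and lower numbers for stronger inhibition), compound 3 gives 50000 nM, level with compound 1 `CCn1cc(CNC(=O)[C@@H](N)CCSC[C@H]2O[C@@H](n3cnc4c(N)ncnc43)[C@H](O)[C@@H]2O)cn1` at 50000 nM and within the scatter of compound 2 `Cc1ccccc1-n1cc(CNC(=O)[C@@H](N)CCSC[C@H]2O[C@@H](n3cnc4c(N)ncnc43)[C@H](O)[C@@H]2O)cn1` at 28000 nM. Compound 4 `Nc1ncnc2c1ncn2[C@@H]1O[C@H](CSCC[C@H](N)C(=O)NCc2cc(C3CCC3)[nH]n2)[C@@H](O)[C@H]1O` differs from compound 3 by a group of 9 heavy atoms (7 carbon, 2 nitrogen; one four-membered non-aromatic ring of carbon only, one five-membered aromatic ring with 2 hetero atoms) in place of a group of 10 heavy atoms (7 carbon, 3 nitrogen; one five-membered aromatic ring with 2 hetero atoms, one six-membered non-aromatic ring with 2 hetero atoms), on a saturated chain carbon bound to an amide-type nitrogen. The two steps that touch this position, no change at the digits printed from compound 1 to compound 3 (within the scatter) and a 1.8-fold higher number from compound 2 to compound 3 (0.25 log units; within the scatter), both stayed within the scatter, so exchanging this side group has so far moved nothing. The step of a 1.3-fold lower number from compound 3 to compound 4 (0.10 log units; within the scatter) is therefore expected to stay within the scatter as well. Compound 4 is estimated at 40000 nM, with a range from 15000 nM to 100000 nM.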

Compound 4, half-maximal inhibitory concentration: 3000 nM
Estimate against measurement, compound 4: 13-fold (1.12 log units) above; measured number outside the range, below it.
By their numbers in this assay, from the lowest: compound 4; then compounds 2, 1 and 3 (each within the scatter of the next).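

This side group, on a saturated chain carbon bound to an amide-type nitrogen, can change the result in this assay: the group with the four-membered carbon ring gives a 17-fold lower number from compound 3 to compound 4 (1.22 log units; beyond the scatter) and a 17-fold lower number from compound 1 to compound 4 (1.22 log units; beyond the scatter) and also a 9.3-fold lower number from compound 2 to compound 4 (0.97 log units; beyond the scatter) and all three steps lie beyond the scatter, unlike the earlier exchanges. No measured evidence here accounts for this change. Still open, going by these compounds, is whether the four-membered ring or the hydrogen-bond donor of the entering group carries the step; a cyclopentyl ring or a plain methyl group in place of that ring would help separate them.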